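This account rests on a few compounds, and the source may have more. Where it says the series, first, only, none or still open, it means among the compounds named here.

Three analogues sharing one core have been examined in an ADME assay on MT4 cells (Homo sapiens) for cytotoxicity, read by MTT assay, with a stated time of 5 days; on this read-out lower numbers stand for higher toxicity in this test and higher numbers for lower toxicity in this test. Compound 1 `COc1cc2nc([S+]([O-])CC(=O)Nc3ccc(Cl)cc3)nc(Nc3c(Cl)cc(/C=C/C#N)cc3Cl)c2cc1OC` gives 14400 nM and compound 3 `COc1cc2nc([S+]([O-])CC(=O)Nc3ccc(C(F)(F)F)cc3)nc(Nc3c(Cl)cc(/C=C/C#N)cc3Cl)c2cc1OC` gives 22000 nM, so that a 1.5-fold higher number from compound 1 to compound 3 (0.18 log units; within the scatter). Compound 2 `COc1cc2nc([S+]([O-])CC(=O)Nc3ccccc3C(F)(F)F)nc(Nc3c(Cl)cc(/C=C/C#N)cc3Cl)c2cc1OC` reaches only the limit of the assay, > 192000 nM. Among the two plain numbers compound 3 stands highest, with compound 1 nearest. Compound 4 `COc1cc2nc([S+]([O-])CC(=O)Nc3ccccc3C#N)nc(Nc3c(Cl)cc(/C=C/C#N)cc3Cl)c2cc1OC` differs from compound 3 by 2-cyanophenyl in place of 4-(trifluoromethyl)phenyl on an amide-type nitrogen. Going by the values given here, two steps bear on this: an at least 13-fold higher number from compound 1 to compound 2 (1.12 log units; beyond the scatter), and an at least 8.7-fold lower number from compound 2 to compound 3 (0.94 log units; beyond the scatter); in both, a 2-substituted phenyl on the amide-type nitrogen goes with the higher number. A large rise is therefore expected for compound 4, possibly up to the limit (the limit of > 192000 nM in this assay, at which 1 of the 3 values shown sits). Compound 4 is estimated at 110000 nM, between 30000 nM and 250000 nM, meaning an expected 5.0-fold higher number from compound 3 to compound 4 (0.70 log units; beyond the scatter).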

Compound 4, half-maximal cytotoxic concentration: > 206000 nM
Compound 4: no number, only a limit; the forecaster's own chance of this, stated with the estimate: 40%; middle value at least 1.8-fold (0.27 log units) away from the limit.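

In this assay compound 4 gives only a limit, not a number: the limit of > 206000 nM in this assay, at which 1 of the 4 values shown sits. With 2-cyanophenyl on the amide-type nitrogen there is an at least 9.3-fold higher number from compound 3 to compound 4 (0.97 log units; beyond the scatter) and an at least 14-fold higher number from compound 1 to compound 4 (1.15 log units; beyond the scatter), so the high end of this read-out is not tied to trifluoromethyl on that phenyl. The step between compound 2 and compound 4 cannot be read, as both values are limits.

Still open, as far as these compounds go, is whether a methoxy group or a carboxylic acid in place of the nitrile would go with an equally high number.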